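The source may hold more compounds than are shown below. What is called first, only, known or untested is meant among the compounds shown, and "the series" means these compounds.

Measured compounds in a functional assay on HEp-2 cells (Homo sapiens) for inhibition, read by sulforhodamine B assay, with a stated time of 48 h, tested at 100 uM; on this read-out lower numbers stand for less inhibition of growth and higher numbers for more inhibition of growth at the one concentration tested:

Compound 1, `O=c1c(C2N=C(c3ccccc3)SS2)coc2ccc(F)cc12`, gives 51%.
Compound 2, `O=c1c(C2N=C(c3ccccc3)SS2)coc2ccccc12`, gives 48%.
Compound 3, `O=c1c(C(=S)Nc2ccccc2)coc2ccccc12`, gives 32%.

Compound 1 and compound 2 share one core and differ by a single change, (fluoro in place of hydrogen on an aromatic carbon). The step it makes is a number 3 percentage points higher from compound 2 to compound 1 (within the scatter). Compound 3 carries a different core; the difference between the two cores is not broken down here, and compound 3 gives the lowest number of the three, beyond the scatter from both others.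

Compound 4, `O=c1c(C(=S)Nc2ccccc2)coc2ccc(F)cc12`, is not yet measured. It differs from compound 3 by fluoro in place of hydrogen on an aromatic carbon, the same change as from compound 2 to compound 1, at a place described in the same words. Since compound 2 to compound 1 gave a number 3 percentage points higher from compound 2 to compound 1 (within the scatter), a step of similar size is expected for compound 4, a number 3 percentage points higher from compound 3 to compound 4 (within the scatter). Compound 4 is therefore estimated at 35%, within 24% to 46%.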

Compound 4, percent growth inhibition at one concentration: 32%
Compound 4: the middle estimate sits 3 percentage points above what was measured; measured number inside the range.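

In this assay, the step for fluoro in place of hydrogen on an aromatic carbon is no change at the digits printed from compound 3 to compound 4 (within the scatter) on the core of compound 3. Set beside the same change on the core of compound 1, the two steps agree: the same change on two cores in this assay, a number 3 percentage points higher (within the scatter) from compound 2 to compound 1 and no change at the digits printed (within the scatter) from compound 3 to compound 4, 3 percentage points apart, within the scatter of two such steps. So on these two cores the change leaves the number within the scatter, but this does not show that it would do so on any other core, at any other place, or in any other assay.

From the compounds shown here alone, it remains open how a different group at this place, such as chloro, an amine or a carboxylic acid, would behave on either core.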